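The compounds below may be only part of what the source reports. "The series", "measured", "known", "first", "only" and "open" are said of these compounds alone.

Measured in a functional assay on Coronary artery (Bos taurus); a higher number here means that more compound is needed for the effect, a lower number that less compound is needed:
- compound 1 `CCCCCNC(=O)NCCCC/C=C\CCCCCS(=O)(=O)c1ccccc1O` gives 5000 nM
- compound 2 `CCCCCNC(=O)NCCCC/C=C\CCCCCCC1=NOS(=O)N1` gives 340 nM
- compound 3 `CCCCCNC(=O)NCCCC/C=C\CCCCCCc1noc(=S)[nH]1` gives 3300 nM

Compound 3 sits level with compound 1, as a 1.5-fold lower number from compound 1 to compound 3 (0.18 log units; within the scatter) shows, and well above compound 2, as a 9.7-fold higher number from compound 2 to compound 3 (0.99 log units; beyond the scatter) shows. Compound 4 `CCCCCNC(=O)NCCCC/C=C\CCCCCCc1nsc(=O)[nH]1` has the same atoms as compound 3, joined differently: a group of 6 heavy atoms (2 carbon, 2 nitrogen, 1 oxygen, 1 sulfur; one five-membered aromatic ring with 3 hetero atoms) in place of a group of 6 heavy atoms (2 carbon, 2 nitrogen, 1 oxygen, 1 sulfur; one five-membered aromatic ring with 3 hetero atoms), on a saturated chain carbon, six bonds along the chain from a double-bonded chain carbon. For the measured compounds named here, the closest precedent is the exchange of one group of 6 heavy atoms for another, a 9.7-fold higher number from compound 2 to compound 3 (0.99 log units; beyond the scatter), which was modest. The larger 15-fold lower number from compound 1 to compound 2 (1.17 log units; beyond the scatter) also shows that this end of the molecule can matter. A step of similar or smaller size is therefore plausible, and a small move towards lower numbers is expected, though the direction is uncertain. The expected step is a 2.8-fold lower number from compound 3 to compound 4 (0.44 log units; beyond the scatter). For compound 4 the estimated value is 1200 nM, with an expected range from 250 nM to 6000 nM.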

Compound 4, half-maximal effective concentration: 2400 nM
Compound 4: middle estimate off by 2.0-fold (0.30 log units), on the low side, and the stated range covers the measured number.
By their numbers in this assay, from the lowest: compound 2; then compounds 4, 3 and 1 (each within the scatter of the next, the first and the last beyond it).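

Rearranging the atoms of the five-membered aromatic ring with 3 hetero atoms, with its count of atoms, donors and acceptors unchanged, leaves no readable difference in this assay (a 1.4-fold lower number from compound 3 to compound 4 (0.14 log units; within the scatter)). The gap to the five-membered non-aromatic ring with 4 hetero atoms of compound 2 remains (a 7.1-fold higher number from compound 2 to compound 4 (0.85 log units; beyond the scatter)), and a modest one appears against the aromatic carbon ring of compound 1 (a 2.1-fold lower number from compound 1 to compound 4 (0.32 log units; beyond the scatter)). No supporting data bear on why these numbers fall as they do. From the compounds shown here alone, whether a carboxylic acid or a tetrazole at this chain end would approach compound 2 remains open.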